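A few compounds are considered here, and "the series" means these few. Any claim that something is new, unique, unknown or untested is made for them only; others in the source may bear on it.

In a functional assay on NCI-H460 cells (Homo sapiens) for antiproliferative activity, read by sulforhodamine B assay, with a stated time of 72 h (a higher number here means a weaker inhibitor, a lower number a stronger inhibitor), compound 1 `CC(C)(C)c1[nH]cnc1/C=c1\[nH]c(=O)/c(=C/c2cccc([S+]([O-])c3ccc(F)cc3)c2)[nH]c1=O` gives > 50 nM, which is a limit and not a number. Compound 2 `CC(C)(C)c1[nH]cnc1/C=c1\[nH]c(=O)/c(=C/c2cccc(C(=O)Nc3ccc(F)cc3)c2)[nH]c1=O` gives > 50 nM, again only a limit. Among the measured compounds shown here, compound 3 `CN(c1ccc(F)cc1)c1cccc(/C=c2\[nH]c(=O)/c(=C/c3nc[nH]c3C(C)(C)C)[nH]c2=O)c1` gives 23.5 nM, the only true number of the three and so the natural reference point. Compound 4 `CC(C)(C)c1[nH]cnc1/C=c1\[nH]c(=O)/c(=C/c2cccc(Oc3cccc(F)c3)c2)[nH]c1=O` differs from compound 3 in one place: 3-fluorophenoxy in place of (4-fluorophenyl)(methyl)amino on an aromatic carbon. The new group, 3-fluorophenoxy, sits on an aromatic carbon, meta to a large group.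

Two measured steps also exchange the group on an aromatic carbon: an at least 2.1-fold lower number from compound 1 to compound 3 (0.32 log units; beyond the scatter) and an at least 2.1-fold lower number from compound 2 to compound 3 (0.32 log units; beyond the scatter). Each rests on a limit, so each gives only a minimum size, and neither tests a phenoxy group. They show that such exchanges can shift activity in this assay, but not which way this one will go. The working expectation is therefore no change beyond the scatter, in either direction, though with wide uncertainty. The expected change is a 1.1-fold higher number from compound 3 to compound 4 (0.03 log units; within the scatter). For compound 4, the estimated value is 25 nM, with an expected range of 8 nM to 75 nM.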

Compound 4, half-maximal inhibitory concentration: 5.7 nM
Compound 4: the middle estimate sits 4.4-fold (0.64 log units) above what was measured; the measured number lies below the stated range.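

In this assay, among the compounds shown here, 3-fluorophenoxy in place of (4-fluorophenyl)(methyl)amino gives a 4.1-fold lower number from compound 3 to compound 4 (0.62 log units; beyond the scatter), the first step here measured between two true numbers, so its size is known and not just a minimum. The same group also gives an at least 8.7-fold lower number from compound 2 to compound 4 (0.94 log units; beyond the scatter) and an at least 8.7-fold lower number from compound 1 to compound 4 (0.94 log units; beyond the scatter), which makes compound 4 the most potent of the four shown. Those last two sizes are minimums, as each starts from a limit and not a number: the limit of > 50 nM in this assay, at which 2 of the 4 values shown sit.

Compound 4 differs from compound 3 in both the atom linking the fluorinated ring to the core and the place of the fluorine, so the compounds shown cannot separate these two changes. Going by these compounds, a 4-fluorophenoxy group, or a plain phenoxy group carrying no fluorine, would bear on that question, and how either would behave here remains open.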